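From Amino to 2-Sulfamoylethyl on a Ring Nitrogen

The source may hold more compounds than are shown below. What is called first, only, known or untested is meant among the compounds shown, and "the series" means these compounds.

Within the data shown here, compound 1 `NNc1nonc1/C(=N/O)Nc1ccc(F)c(Br)c1` is one of two compounds measured so far; in an assay on isolated protein for inhibition of Indoleamine 2,3-dioxygenase 1 (Homo sapiens), read by fluorescence, with a stated time of 60 min (on this read-out lower numbers stand for stronger inhibition and higher numbers for weaker inhibition), compound 1 gives 108 nM. The other, compound 2 `O=S1(=O)CC(Nc2nonc2/C(=N/O)Nc2ccc(F)c(Br)c2)C1`, gives 99 nM and lies within the scatter of compound 1: the step of a 1.1-fold lower number from compound 1 to compound 2 (0.04 log units; within the scatter) replaced the amino with a larger group and left the number essentially unchanged. Compound 3 `NS(=O)(=O)CCNc1nonc1/C(=N/O)Nc1ccc(F)c(Br)c1` makes a related change at the same nitrogen: 2-sulfamoylethyl in place of amino on a nitrogen on an aromatic ring. Because a 1.1-fold lower number from compound 1 to compound 2 (0.04 log units; within the scatter) stayed within the scatter, no movement beyond the scatter is expected, a 1.1-fold lower number from compound 1 to compound 3 (0.03 log units; within the scatter). Compound 3 is therefore estimated at 100 nM, with a range of 40 nM to 250 nM.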

Compound 3, half-maximal inhibitory concentration: 71 nM
Estimate against measurement, compound 3: 1.4-fold (0.15 log units) above; low and high end bracket the measured number.
By their numbers in this assay, from the lowest: compounds 3, 2 and 1 (each within the scatter of the next).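

In this assay, the open-chain 2-sulfamoylethyl on this nitrogen shows that a second large group, this time without a ring, also leaves the number level with amino: a 1.5-fold lower number from compound 1 to compound 3 (0.18 log units; within the scatter). Exchanging the four-membered ring group for this chain changes no more: a 1.4-fold lower number from compound 2 to compound 3 (0.14 log units; within the scatter). No measurement shown offers an explanation for how closely these numbers agree.

Still open, from the compounds shown here alone, is whether a carboxylic acid or a longer chain on this nitrogen would also stay within the scatter.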